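The compounds below may be only part of what the source reports. "The series", "measured", "known", "first", "only" and "open" are said of these compounds alone.

Of the compounds shown here, three with a shared core have been tested in a functional assay on SW-620 cells (Homo sapiens) for antiproliferative activity, read by MTT assay, with a stated time of 24 h; a lower number here means a stronger inhibitor, a higher number a weaker inhibitor. Compound 1 (`COc1ccc(C(=O)/C=C/c2cccc(F)c2)c2c1C=CC(C)(C)O2`) gives > 10000 nM, and this is a limit of the assay, not a number. Compound 2 (`COc1ccc(C(=O)/C=C/c2ccc(N(C)C)cc2)c2c1C=CC(C)(C)O2`) gives 570 nM. Within the data shown here, compound 3 (`CCN(CC)c1ccc(/C=C/C(=O)c2ccc(OC)c3c2OC(C)(C)C=C3)cc1`) gives 670 nM, which makes it one of only two compounds with a true number. The step between those two is a 1.2-fold higher number from compound 2 to compound 3 (0.07 log units; within the scatter), so they stand level.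

Compound 4 (`COc1ccc(C(=O)/C=C/c2ccccc2)c2c1C=CC(C)(C)O2`) carries hydrogen in place of diethylamino on an aromatic carbon, para to a large group: hydrogen in place of diethylamino on an aromatic carbon. Swapping one amino group for the other barely registered, so the more telling comparison involves a compound with no amino group at all. Compound 4 likewise has no amino group, so with an at least 17-fold lower number from compound 1 to compound 2 (1.24 log units; beyond the scatter) as the guide, a large move towards a higher number is expected in this assay. The match is imperfect, as compound 4 also lacks the fluorine of compound 1.

That expectation amounts to a 9.0-fold higher number from compound 3 to compound 4 (0.95 log units; beyond the scatter). For compound 4 the estimate is 6000 nM, expected to lie between 1500 nM and 20000 nM.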

Compound 4, half-maximal inhibitory concentration: > 10000 nM
Compound 4: a limit, no number (the forecaster's own chance of this, stated with the estimate: 40%); middle value at least 1.6-fold (0.22 log units) away from the limit.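

In this assay, exchanging one amino group for the other changed little, but removing the amino group altogether matters: hydrogen on this aromatic carbon, para to a large group, gives an at least 14-fold higher number from compound 3 to compound 4 (1.17 log units; beyond the scatter), and likewise an at least 17-fold higher number from compound 2 to compound 4 (1.24 log units; beyond the scatter). The earlier large step also involved a fluoro group, whereas these two steps replace only the amino group with hydrogen, so the drop ties directly to losing that group. Compound 4 gives a limit of the assay, not a number, so both steps show only a minimum size, and the step from compound 1 cannot be read: the limit of > 10000 nM in this assay, at which 2 of the 4 values shown sit.

The compounds shown carry only dimethylamino and diethylamino at this place. Going by these compounds, whether a primary amine, a morpholine ring or a methoxy group would do as well remains open.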